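The source may hold more compounds than are shown below. What is called first, only, known or untested is meant among the compounds shown, and "the series" means these compounds.

Working notes on the series. The reference point for the whole set is a functional assay on the whole organism for inhibition, with Rattus norvegicus as the target, at a dose of 5 mg/kg by the intraperitoneal route; a lower number here means less inhibition, a higher number more inhibition at the dose given (going by the name of the read-out). Compound 1 `CCCN(CCC)C1CCc2c[nH]cc2C1` gives 93% in this assay, and compound 2 `NC1CCc2c[nH]cc2C1` gives 24% in this assay. Compound 3 `CN(C)C1CCc2n[nH]cc2C1` gives 69% in this assay, which places it second of the three: compound 1 lies beyond the scatter above it, and compound 2 lies further below it, also beyond the scatter.

The next compound, compound 4 `NC1CCc2n[nH]cc2C1`, is not yet measured in this assay. It differs from compound 3 in one place: amino in place of dimethylamino on a saturated ring carbon.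

Among the compounds with values here, no single-change step between measured compounds is available to set the size of this move. What the two values of compound 1 and compound 2 show is that, on the core of compound 1, the amino compound sits far below the dialkylamino one. On that basis a drop beyond the scatter is expected here too, and the step of a number 39 percentage points lower from compound 3 to compound 4 (beyond the scatter) is the estimated size. Compound 4 is expected to give about 30% in this assay, with a range from 10% to 55%.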

Compound 4, a percentage reported as inhibition, in the whole organism at one dose (the size of the read-out at that dose, not a potency): 14%
Estimate against measurement, compound 4: 16 percentage points above; measured number inside the range.
By their numbers in this assay, from the lowest: compounds 4 and 2 (each within the scatter of the next); then compound 3; then compound 1.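

In this assay, within the data shown here, a number 55 percentage points lower from compound 3 to compound 4 (beyond the scatter) gives the first measured single-change step, and it is large: on this core, the dimethylamino group on the saturated ring carbon cannot be replaced by amino without losing most of the inhibition at the dose given. The dialkylamino substitution at this position therefore matters directly, and this no longer rests on a comparison across the series. The two amino compounds, compound 2 (24%) and compound 4 (14%), lie within the scatter of each other, so the change of core between them shows no effect on this read-out.

Nothing measured here explains the size of the step. Open, going by these compounds, is how inhibition responds between the two ends of this change, as with a methylamino or diethylamino group on the same ring carbon.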